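This account rests on a few compounds, and the source may have more. Where it says the series, first, only, none or still open, it means among the compounds named here.

Of the compounds shown here, three built on the shared core have so far been tested in a functional assay on HL-60 cells (Homo sapiens) for inhibition, read by CCK-8 assay, with a stated time of 48 h; a lower number here means a stronger inhibitor, a higher number a weaker inhibitor. Compound 1 `COc1cccc(NC(=S)NCCNS(=O)(=O)c2ccc(-c3ccccc3Oc3ccc([N+](=O)[O-])cc3)s2)c1` reaches only a limit in this assay, > 50000 nM, and the evidence records that (the limit of > 50000 nM in this assay, at which 1 of the 3 values shown sits). Compound 3 `O=C(NCCNS(=O)(=O)c1ccc(-c2ccccc2Oc2ccc([N+](=O)[O-])c([N+](=O)[O-])c2)s1)Nc1ccc(Cl)cc1` gives 8100 nM in this assay. Compound 2 `O=C(NCCNS(=O)(=O)c1ccc(-c2ccccc2OCc2ccccc2)s1)Nc1cc(C(F)(F)F)cc(C(F)(F)F)c1` gives 11400 nM in this assay, the highest of the two numbers reported, although its gap to compound 3 lies within the scatter, so the two cannot be ranked against each other.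

Compound 4 `Nc1ccc(Oc2ccccc2-c2ccc(S(=O)(=O)NCCNC(=O)Nc3cc(C(F)(F)F)cc(C(F)(F)F)c3)s2)cc1` has not yet been measured. It differs from compound 2 in one place: 4-aminophenyl in place of benzyl on an oxygen on an aromatic ring. Among the measured compounds shown here, no pair of measured compounds differing in a single place is available, so this step has no direct precedent in the set. A modest lowering of the number, or none beyond the scatter, is expected, since compound 3 gives 8100 nM in this assay. The step from compound 2 to compound 4 is expected to be a 1.4-fold lower number from compound 2 to compound 4 (0.15 log units; within the scatter). Compound 4 is estimated at 8000 nM in this assay, within a range from 2500 nM to 30000 nM.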

Compound 4, half-maximal inhibitory concentration: > 50000 nM
Compound 4 gave a limit, no number (the forecaster's own chance of this, stated with the estimate: 10%); middle value at least 6.2-fold (0.79 log units) away from the limit.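

Among the compounds shown here, replacing benzyl with 4-aminophenyl on the oxygen on the aromatic ring gives the first single-place step in this set, and that step is beyond the scatter: it is an at least 4.3-fold higher number from compound 2 to compound 4 (0.64 log units; beyond the scatter). The earlier compounds shown here offered no such pair, so only now is the number seen to respond to the group at this position, even though the two groups match in heavy atoms and each holds one six-membered aromatic ring of carbon only. Compound 4 gives a limit rather than a number in this assay, so the full size of the step stays unknown: the limit of > 50000 nM in this assay, at which 2 of the 4 values shown sit.

The compounds shown do not tell whether the amine of the 4-aminophenyl or the shift from benzyloxy to a phenoxy link carries the step. A plain phenyl or a 4-methoxyphenyl on the same oxygen, with the rest as in compound 2, lies outside them.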